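Naphthyl to phenyl on the thioether arm

A few compounds are considered here, and "the series" means these few. Any claim that something is new, unique, unknown or untested is made for them only; others in the source may bear on it.

In a functional assay on HeLa cells (Homo sapiens) for cytotoxicity, read by MTT assay, with a stated time of 72 h (a lower number here means a stronger inhibitor, a higher number a weaker inhibitor), compound 1 `Cc1cc(-c2ccccc2)n(/C(N)=N/S(=O)(=O)c2cc(C)c(Cl)cc2SCc2cccc3ccccc23)n1` gives 3000 nM, the lowest of the two numbers recorded. Compound 2 `Cc1cc(S(=O)(=O)/N=C(\N)n2nccc2-c2ccccc2)c(SCc2cccc(Cl)c2)cc1Cl` gives 10000 nM in this assay, a gap from compound 1 that lies beyond the scatter. Compound 3 `Cc1cc(-c2ccccc2)n(/C(N)=N/S(=O)(=O)c2cc(C)c(Cl)cc2SCc2ccccc2)n1` carries the change (phenyl in place of naphthalen-1-yl on a saturated chain carbon bound to a sulfur). Among the compounds with values here, no pair of measured compounds isolates this change, so the expectation rests on compound 1 alone. A small weakening of potency, a 1.7-fold higher number from compound 1 to compound 3 (0.22 log units; within the scatter), is expected, possibly none beyond the scatter. Compound 3 is estimated at 5000 nM in this assay, with a range from 2000 nM to 15000 nM.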

Compound 3, half-maximal inhibitory concentration: 5000 nM
The estimate for compound 3 equals the measured number at the digits printed; the range from low to high includes it.
By their numbers in this assay, from the lowest: compounds 1, 3 and 2 (each within the scatter of the next, the first and the last beyond it).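

In this assay, phenyl in place of naphthalen-1-yl on a saturated chain carbon bound to a sulfur gives a 1.7-fold higher number from compound 1 to compound 3 (0.22 log units; within the scatter). This position therefore accepts one aromatic ring of carbon in place of two with no change that can be told from the scatter, so the second ring is not needed for the activity read here. No measurement on hand gives a reason for this result. Still open, from the compounds shown here alone, is how an amine or a carboxylic acid on the phenyl ring would read, and how a longer chain on the sulfur would read.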